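Second Benzoyl on the Amide Nitrogen of Compound 1

A few compounds are considered here, and "the series" means these few. Any claim that something is new, unique, unknown or untested is made for them only; others in the source may bear on it.

Compound 1 `Cc1nc(NC(=O)c2ccccc2)c2nn(-c3ccccc3)cc2n1` gives 30% in an assay on CHO cells for displacement of a labelled ligand from adenosine receptor A1 (Homo sapiens), read by scintillation counting, with a stated time of 120 min, tested at 1 uM (on this read-out higher numbers stand for more inhibition at the one concentration tested (going by the name of the read-out) and lower numbers for less inhibition), the highest of the three numbers shown, though compound 2 `CC(=O)Nc1nc(C)nc2cn(-c3ccccc3)nc12` with 25% lies within the scatter of it, while compound 3 `O=C(Nc1nc(-c2ccccc2)nc2cn(-c3ccccc3)nc12)c1ccccc1` with 5% falls clearly lower. The step from compound 1 to compound 2 was a number 5 percentage points lower from compound 1 to compound 2 (within the scatter), and the step to compound 3 was a number 25 percentage points lower from compound 1 to compound 3 (beyond the scatter). Compound 4 `Cc1nc(N(C(=O)c2ccccc2)C(=O)c2ccccc2)c2nn(-c3ccccc3)cc2n1` differs from compound 1 by benzoyl in place of hydrogen on an amide-type nitrogen. Among the compounds with values here, no measured step adds a second acyl group to that nitrogen; the nearest precedent, the exchange at the carbonyl carbon, changed little. Compound 4 is therefore expected to give 15%, between 0% and 35%, an estimated step of a number 15 percentage points lower from compound 1 to compound 4 (beyond the scatter).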

Compound 4, a percentage reported as inhibition, at one concentration (the size of the read-out at that concentration, not a potency): 6%
For compound 4 the middle estimate is 9 percentage points above the measured one; the range from low to high includes it.
By their numbers in this assay, from the lowest: compounds 3 and 4 (each within the scatter of the next); then compounds 2 and 1 (each within the scatter of the next).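

In this assay, benzoyl in place of hydrogen on the amide-type nitrogen gave a number 24 percentage points lower from compound 1 to compound 4 (beyond the scatter), showing that this nitrogen is sensitive to substitution by a second benzoyl. The exchange at the carbonyl carbon, by contrast, gave a number 5 percentage points lower from compound 1 to compound 2 (within the scatter). Nothing available explains the difference between these two changes. The compounds shown leave open whether the loss is particular to benzoyl or would also follow an ethyl chain or an aminoethyl chain on that nitrogen.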